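Tolerated concentration across three amide variants of one core

The source may report more compounds than this note shows. Statements on the series, on what has been measured and on what is new or still open speak of the compounds shown alone.

Compound 1 `Cc1cc(C)cc(S(=O)(=O)c2c(C(=O)NCc3cccc(F)c3F)[nH]c3ccc(Cl)cc23)c1` carries 2,3-difluorophenyl on the saturated chain carbon bound to the amide-type nitrogen. In an ADME assay on MT4 cells (Homo sapiens) for cytotoxicity, read by MTT assay (a higher number here means that more compound is tolerated, a lower number that less compound is tolerated), compound 1 reaches only a limit of the assay, > 51100 nM. Compound 2 `Cc1cc(C)cc(S(=O)(=O)c2c(C(=O)NCc3ccc4nc(N)[nH]c4c3)[nH]c3ccc(Cl)cc23)c1` carries 2-amino-1H-benzimidazol-6-yl in that place, and in this assay compound 2 gives 5890 nM. Within the data shown here, of the two values shown, compound 2 holds the only number; the other value is a limit. Among the measured compounds shown here, the one measured step is an at least 8.6-fold lower number from compound 1 to compound 2 (0.93 log units; beyond the scatter).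

Compound 3 `Cc1cc(C)cc(S(=O)(=O)c2c(C(=O)NC(C)c3cc(F)cc(F)c3)[nH]c3ccc(Cl)cc23)c1` is not yet measured. The change from compound 2: a group of 10 heavy atoms (8 carbon, 2 fluorine; one six-membered aromatic ring of carbon only) in place of a group of 11 heavy atoms (8 carbon, 3 nitrogen; one five-membered aromatic ring with 2 hetero atoms, one six-membered aromatic ring of carbon only), on an amide-type nitrogen. The measured step of an at least 8.6-fold lower number from compound 1 to compound 2 (0.93 log units; beyond the scatter) runs in the structurally opposite sense, from a fluorinated phenyl toward the benzimidazolyl, and its starting point is only the limit (the limit of > 51100 nM in this assay, at which 1 of the 2 values shown sits). Returning to a fluorinated phenyl, here with an added methyl on the chain carbon, is therefore expected to raise the number, the estimated step being a 6.8-fold higher number from compound 2 to compound 3 (0.83 log units; beyond the scatter). For compound 3 the expected value is 40000 nM, within 12000 nM to 70000 nM, with a fair chance that only a limit is reported.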

Compound 3, half-maximal cytotoxic concentration: > 49700 nM
Compound 3: no number, only a limit (the forecaster's own chance of this, stated with the estimate: 45%); at least 1.2-fold (0.09 log units) between middle value and limit.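

With 1-(3,5-difluorophenyl)ethyl on the amide-type nitrogen, this assay shows an at least 8.4-fold higher number from compound 2 to compound 3 (0.92 log units; beyond the scatter), so a second group carrying a fluorinated phenyl stands apart from the 2-amino-1H-benzimidazol-6-yl group. Among these three amide variants, the only number so far belongs to the compound with that benzimidazolyl group, while the step between compound 1 and compound 3 cannot be read, and the added chain methyl and the moved fluorines therefore remain without a measured effect here. Compound 3 gives only a limit: the limit of > 49700 nM in this assay, at which 1 of the 3 values shown sits.

Which part of the 2-amino-1H-benzimidazol-6-yl group goes with the lower number stays open: a benzimidazol-6-yl group without the amine, or a simple aminophenyl group, would separate the amine from the rest of the group. As far as these compounds go, it also stays open how much the chain methyl and the fluorine pattern each contribute, and 1-(2,3-difluorophenyl)ethyl on the amide-type nitrogen would change only the chain relative to compound 1.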